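From Bromo to a Carbamate Handle on the Shared Core

The source may report more compounds than this note shows. Statements on the series, on what has been measured and on what is new or still open speak of the compounds shown alone.

Compound 3 `Cc1nc2c(OCc3ccccc3)cccn2c1Br` was tested in a functional assay on the whole organism (stomach) for inhibition, with Canis familiaris (Canis lupus familiaris) as the target, at a dose of 5 mg/kg by the intravenous route (a lower number here means a weaker effect, a higher number a stronger effect of the compound at the dose given), where compound 3 gives 63%. Among the three measured compounds this is the second highest number. Its nearest neighbour is compound 1 `Cc1cn2cccc(OCc3ccccc3)c2n1`, which in this assay gives 70%; the step of a number 7 percentage points lower from compound 1 to compound 3 (within the scatter) lies within the scatter, so the two cannot be told apart. Furthest away is compound 2 `Cc1nc2c(OCc3ccccc3)cccn2c1C#N`, which gives 4%; the step of a number 59 percentage points higher from compound 2 to compound 3 (beyond the scatter) is beyond the scatter and large.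

Compound 4 `Cc1nc2c(OCc3ccccc3)cccn2c1COC(=O)N(C)C` differs from compound 3 in one place: ((dimethylcarbamoyl)oxy)methyl in place of bromo on an aromatic carbon.

All three measured steps change the same aromatic carbon, so all bear on this. Hydrogen and bromo there behave alike, while the cyano group wipes out most of the effect, as the step of a number 66 percentage points lower from compound 1 to compound 2 (beyond the scatter) shows. The position therefore accepts some groups and rejects others, and nothing measured resembles the seven-atom group that now enters. A sizeable change in either direction is possible; the safer expectation is a loss of moderate size. Compound 4 is expected to give 40%, within a range from 5% to 80%. That corresponds to an expected step of a number 23 percentage points lower from compound 3 to compound 4 (beyond the scatter).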

Compound 4, a percentage reported as inhibition, in the whole organism at one dose (the size of the read-out at that dose, not a potency): 23%
For compound 4 the middle estimate is 17 percentage points above the measured one; the range from low to high includes it.
By their numbers in this assay, from the lowest: compound 2; then compound 4; then compounds 3 and 1 (each within the scatter of the next).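

The change appears as a number 40 percentage points lower from compound 3 to compound 4 (beyond the scatter) and as a number 47 percentage points lower from compound 1 to compound 4 (beyond the scatter) in this assay, so this position, which treats hydrogen and bromo alike, does not carry a ((dimethylcarbamoyl)oxy)methyl group of 7 heavy atoms equally well. The same group still stands clear of the nitrile, as a number 19 percentage points higher from compound 2 to compound 4 (beyond the scatter) shows, so the position now gives three levels rather than two: hydrogen and bromo together, the carbamate-bearing group lower, and the nitrile lowest. Group size alone does not set this order, since compound 2 goes against it: its nitrile gives the lowest number, although the largest group among these compounds sits on compound 4.

Nothing measured on these compounds says why the groups rank in this way.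
Going by these compounds, it also stays open whether the loss belongs to the carbamate end of the group or to the chain as a whole, a question that a plain hydroxymethyl, methoxymethyl or aminomethyl group on the same aromatic carbon could help to separate.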